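From pyridin-3-yl to cyclooctyl on the shared core

The source may report more compounds than this note shows. Statements on the series, on what has been measured and on what is new or still open speak of the compounds shown alone.

In a functional assay on PC-3 cells (Homo sapiens) for cytotoxicity, read by WST assay, with a stated time of 72 h (a higher number here means a weaker inhibitor, a lower number a stronger inhibitor), compound 1 `O=C1Nc2c(ccc(F)c2F)C1(c1ccc(O)cc1)c1cccnc1` gives > 1000 nM and this is a limit, not a number. Compound 2 `O=C1Nc2c(ccc(F)c2F)C1(c1ccc(O)cc1)C1CCCCC1` gives 9.2 nM; 32 nM; > 1000 nM (3 entries) in this assay over repeated entries. Compound 3 `O=C1Nc2c(ccc(F)c2F)C1(c1ccc(O)cc1)C1CCCCCCC1` has cyclooctyl in place of pyridin-3-yl on a saturated ring carbon, with cyclooctyl in place of pyridin-3-yl on a saturated ring carbon as the counted change. Compound 2 also bears a non-aromatic ring of carbon only there, so with 9.2 nM; 32 nM; > 1000 nM (3 entries) as the guide a step toward stronger inhibition in this assay is expected, though the spread of those entries keeps it uncertain. The expected size is an at least 25-fold lower number from compound 1 to compound 3 (1.39 log units; beyond the scatter) in this estimate. In this assay compound 3 is estimated at 40 nM with a range from 8 nM to 600 nM overall.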

Compound 3, half-maximal inhibitory concentration: > 1000 nM
Compound 3: only a limit was reported (the forecaster's own chance of this, stated with the estimate: 15%); middle value at least 25-fold (1.39 log units) away from the limit.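

Within the data shown here, compound 1 and compound 3 both stand only as limits in this assay, so no step between them can be read. Still open is how cyclooctyl and pyridin-3-yl compare on the shared core, and how either compares with compound 2, whose entries spread widely: the several entries of compound 2 in this assay, 9.2 nM; 32 nM; > 1000 nM (3 entries)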